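Methoxypyridine in place of ethylphenyl: an expected weakening

The compounds below may be only part of what the source reports. "The series", "measured", "known", "first", "only" and "open" are said of these compounds alone.

Measured in an assay on CHO cells, read by calcium flux; a higher number here means a weaker inhibitor, a lower number a stronger inhibitor:
Compound 1, `CCc1ccc(NC(=O)c2csc(Cc3c(Cl)cccc3Cl)n2)cc1`: 810 nM.
Compound 2, `CN(C)c1ccc(NC(=O)c2csc(Cc3c(Cl)cccc3Cl)n2)cc1`: only a limit of the assay, > 4000 nM.
Compound 3, `O=C(Nc1ccc(C(F)(F)F)cc1)c1csc(Cc2c(Cl)cccc2Cl)n1`: 140 nM.

Of the two numbers, compound 1 gives the higher one; the step of a 5.8-fold lower number from compound 1 to compound 3 (0.76 log units; beyond the scatter) is modest and beyond the scatter. Compound 2 sits at a limit (the limit of > 4000 nM in this assay, at which 1 of the 3 values shown sits), so an at least 4.9-fold higher number from compound 1 to compound 2 (0.69 log units; beyond the scatter) is known only as a lower bound. Compound 4, `COc1ccc(NC(=O)c2csc(Cc3c(Cl)cccc3Cl)n2)cn1`, differs from compound 1 by 6-methoxypyridin-3-yl in place of 4-ethylphenyl on an amide-type nitrogen. The two measured steps both alter the same aromatic carbon, one way weakening, the other strengthening; here the whole ring changes. Compound 4 is expected to be somewhat weaker, a 2.5-fold higher number from compound 1 to compound 4 (0.39 log units; beyond the scatter), with an estimated value of 2000 nM, between 600 nM and 7000 nM.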

Compound 4, half-maximal inhibitory concentration: > 4000 nM
Compound 4 was reported as a limit (the forecaster's own chance of this, stated with the estimate: 30%); middle value at least 2.0-fold (0.30 log units) away from the limit.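

In this assay, exchanging the whole 4-ethylphenyl for 6-methoxypyridin-3-yl on the amide-type nitrogen gives an at least 4.9-fold higher number from compound 1 to compound 4 (0.69 log units; beyond the scatter), a step known only as a lower bound. Going by these compounds alone, compound 4 gives a limit of the assay, not a number: the limit of > 4000 nM in this assay, at which 2 of the 4 values shown sit. The earlier steps changed only the group on an aromatic carbon, whereas this one shows that inhibition also weakens when the ring itself is replaced.

This single change alters the ring and its substituent together, so the contributions of the ring nitrogen and the methoxy group remain unseparated. A methoxyphenyl group or an ethylpyridinyl group would tell them apart.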